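A few compounds are considered here, and "the series" means these few. Any claim that something is new, unique, unknown or untested is made for them only; others in the source may bear on it.

Compound 2 `Cc1ccc(S(=O)(=O)/N=C(/CCNC2=CC(=O)c3ccccc3C2=O)Nc2cccc(C(F)(F)F)c2)cc1` is the weaker of the two inhibitors measured in a functional assay on HeLa cells (Homo sapiens) for cytotoxicity, read by MTT assay, with a stated time of 48 h; a lower number here means a stronger inhibitor, a higher number a weaker inhibitor. Among the compounds with values here, compound 1 `Cc1ccc(S(=O)(=O)/N=C(/CCNC2=CC(=O)c3ccccc3C2=O)Nc2ccc(F)cc2)cc1` gives 5890 nM in this assay, and compound 2 gives 77600 nM; the one step between them, a 13-fold higher number from compound 1 to compound 2 (1.12 log units; beyond the scatter), is the only measured step and is well beyond the scatter.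

Compound 3 `COc1ccc(N/C(CCNC2=CC(=O)c3ccccc3C2=O)=N\S(=O)(=O)c2ccc(C)cc2)cc1OC` is not yet measured. It differs from compound 2 by 3,4-dimethoxyphenyl in place of 3-(trifluoromethyl)phenyl on an amine nitrogen. Within the data shown here, the only step that bears on this position is the step from compound 1 to compound 2, which shows that the group on this amine nitrogen moves the number by a large amount. Nothing measured shows what a 3,4-dimethoxyphenyl group does at this place; the data only show that the 3-(trifluoromethyl)phenyl group of compound 2 sits at the high end. Since that group leaves, the expected step of a 5.2-fold lower number from compound 2 to compound 3 (0.71 log units; beyond the scatter) is downward, toward the number of compound 1, with wide uncertainty. Compound 3 is therefore expected to give about 15000 nM in this assay, with a range from 4000 nM to 60000 nM.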

Compound 3, half-maximal inhibitory concentration: 14500 nM
Compound 3: middle estimate off by 1.0-fold (0.01 log units), on the high side; the measured number falls inside the stated range.
By their numbers in this assay, from the lowest: compound 1; then compound 3; then compound 2.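

In this assay, a 5.4-fold lower number from compound 2 to compound 3 (0.73 log units; beyond the scatter) shows that the high number of compound 2 is not shared by every substituted aryl group on this amine nitrogen: exchanging 3-(trifluoromethyl)phenyl for 3,4-dimethoxyphenyl, a swap of equal heavy-atom count in which 0 hydrogen-bond acceptors become 2, brings the number down by an amount beyond the scatter. The a 2.5-fold higher number from compound 1 to compound 3 (0.39 log units; beyond the scatter) is also beyond the scatter, so 3,4-dimethoxyphenyl does not match 4-fluorophenyl, and the three groups now give three separate levels at this position, with compound 3 lying in the middle. No measurement on hand gives a reason for either step, so the order stands as an observation only.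

The compounds shown leave open how an unsubstituted phenyl, a phenyl with a single methoxy group, or a short alkyl chain in place of the aryl group would read on this amine nitrogen, so the separate contributions of the two methoxy groups in compound 3 remain unresolved. They also leave open whether the same order of the three groups would hold with a different group elsewhere on the shared core.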